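Trifluoromethoxy in place of trifluoromethyl: step to compound 4

This account rests on a few compounds, and the source may have more. Where it says the series, first, only, none or still open, it means among the compounds named here.

In an ADME assay on J774 cells (Mus musculus) for antiproliferative activity, with a stated time of 72 h (a lower number here means that less compound is needed, a higher number that more compound is needed for the effect), compound 1 `CCCCc1cc2c(=O)c(CC)c(C)[nH]c2cc1OCCOc1ccccc1`, which carries ethyl, gives 1000 nM. With pyridin-3-yl on that aromatic carbon, compound 2 `CCCCc1cc2c(=O)c(-c3cccnc3)c(C)[nH]c2cc1OCCOc1ccccc1` gives 23000 nM. With 4-(trifluoromethyl)phenyl there, compound 3 `CCCCc1cc2c(=O)c(-c3ccc(C(F)(F)F)cc3)c(C)[nH]c2cc1OCCOc1ccccc1` gives 20000 nM. Compound 3 therefore stands well above compound 1 in this assay, with a 20-fold higher number from compound 1 to compound 3 (1.30 log units; beyond the scatter), and level with compound 2 within the scatter, with a 1.2-fold lower number from compound 2 to compound 3 (0.06 log units; within the scatter). The entry for compound 2 is similar, with a 23-fold higher number from compound 1 to compound 2 (1.36 log units; beyond the scatter).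

Compound 4 `CCCCc1cc2c(=O)c(-c3ccc(OC(F)(F)F)cc3)c(C)[nH]c2cc1OCCOc1ccccc1` has trifluoromethoxy in place of trifluoromethyl on an aromatic carbon, para to a large group: trifluoromethoxy in place of trifluoromethyl on an aromatic carbon. The same difference reads as 4-(trifluoromethyl)phenyl to 4-(trifluoromethoxy)phenyl. Among the compounds with values here, no measured pair makes this exact exchange. The two large steps replace ethyl with a ring, and compound 4 keeps a ring there, so they offer little guidance here. Within the data shown here, the closest precedent is the exchange between the two ring groups in compound 2 and compound 3, a 1.2-fold lower number from compound 2 to compound 3 (0.06 log units; within the scatter), which stayed within the scatter. A similarly small change is expected here, with no step beyond the scatter. The expected step is no change at the digits printed from compound 3 to compound 4 (within the scatter). For compound 4 the estimated value is 20000 nM, with an expected range of 8000 nM to 45000 nM.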

Compound 4, half-maximal effective concentration: 20000 nM
The estimate for compound 4 equals the measured number at the digits printed, within the range that was stated.
By their numbers in this assay, from the lowest: compound 1; then compounds 3, 4 and 2 (each within the scatter of the next).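

Working notes: in this assay, the step for trifluoromethoxy in place of trifluoromethyl on an aromatic carbon, para to a large group, is the first direct reading of this exchange (no change at the digits printed from compound 3 to compound 4 (within the scatter)), and it shows no change at this position despite the added oxygen and hydrogen-bond acceptor. Compound 4 also lies within the scatter of the pyridin-3-yl compound (a 1.2-fold lower number from compound 2 to compound 4 (0.06 log units; within the scatter)) while remaining far from the ethyl compound (a 20-fold higher number from compound 1 to compound 4 (1.30 log units; beyond the scatter)), so compounds 2, 3 and 4 now form one level, with compound 1 alone apart and no shown compound going against that split. No measured property is available to explain this level or the gap to compound 1.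

On these data alone, it remains open whether an amine or a carboxylic acid in place of trifluoromethoxy on this phenyl ring would leave the number at the same level. The range between ethyl and the ring groups is also unresolved, since a longer chain such as butyl or an unsubstituted phenyl could show where along that range the large step arises.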